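The source may report more compounds than this note shows. Statements on the series, on what has been measured and on what is new or still open speak of the compounds shown alone.

Working notes on the stilbene series.

Compound 1 `COc1cc(/C=C/c2ccc(N(C)C)c([N+](=O)[O-])c2)cc(OC)c1OC` carries a nitro group on the ring bearing the dimethylamino group. In a functional assay on HT-29 cells (Homo sapiens) for inhibition (on this read-out lower numbers stand for stronger inhibition and higher numbers for weaker inhibition), compound 1 sits at a limit, > 5000 nM, with no number beyond it. Compound 2 `COc1cc(/C=C/c2ccc(N(C)C)c(N)c2)cc(OC)c1OC` is its amino counterpart and in this assay compound 2 gives 300 nM. The change amino in place of nitro on an aromatic carbon therefore produced an at least 16-fold lower number from compound 1 to compound 2 (1.22 log units; beyond the scatter); the size of this step rests on the limit of > 5000 nM in this assay, at which 1 of the 3 values shown sits, at which compound 1 sits.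

Compound 3 `COc1cc(/C=C/c2ccc3ccccc3c2)cc([N+](=O)[O-])c1OC` has a different core; the difference between the two cores is not broken down here. In this assay compound 3 also sits at a limit, > 10000 nM, as noted by the limit of > 10000 nM in this assay, at which 1 of the 3 values shown sits. Compound 4 `COc1cc(/C=C/c2ccc3ccccc3c2)cc(N)c1OC` is not yet measured; it differs from compound 3 by amino in place of nitro on an aromatic carbon, the same kind of change as between compound 1 and compound 2, but here the position is ortho to a methoxy group and meta to a methoxy group rather than ortho to a dimethylamino group.

Given the large step seen in compound 2, a step of an at least 5.0-fold lower number from compound 3 to compound 4 (0.69 log units; beyond the scatter) is expected from compound 3 to compound 4, though the core differs. Compound 4 is estimated at 2000 nM in this assay, between 300 nM and 10000 nM.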

Compound 4, half-maximal inhibitory concentration: 6000 nM
Compound 4: middle estimate off by 3.0-fold (0.48 log units), on the low side; the measured number falls inside the stated range.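

In this assay, amino in place of nitro on an aromatic carbon gives an at least 1.6-fold lower number from compound 3 to compound 4 (0.22 log units; that floor lies within the scatter), so on the core of compound 3 the step is known only as a floor. Compound 3 stands at > 10000 nM, which is a limit and not a number. The series therefore does not show that the change keeps its size from one core to the other, nor that its size depends on the core: the same change on two cores in this assay, an at least 16-fold lower number (1.22 log units; beyond the scatter) from compound 1 to compound 2 and an at least 1.6-fold lower number (0.22 log units; that floor lies within the scatter) from compound 3 to compound 4; the limit leaves it open whether they differ

Still open, as far as these compounds go, is how far a group other than amino would carry at this place on either core, for example a hydroxyl, a methylamino or an acetamide in place of the nitro. Also open, from the compounds shown here alone, is the true size of the step on each core, since a limit stands at the nitro end of both pairs.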